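The compounds below may be only part of what the source reports. "The series", "measured", "known", "first", "only" and "open" are said of these compounds alone.

Of the compounds shown here, three built on one shared core have been measured in a functional assay on isolated protein for inhibition of Glucose-dependent insulinotropic receptor (Homo sapiens), read by HTRF and cAMP accumulation; a higher number here means that more compound is needed for the effect, a lower number that less compound is needed. Compound 1 `Cc1nc(S(C)(=O)=O)ccc1Oc1ncnc(OC2CCN(C(=O)OC(C)(C)C#N)CC2)c1F` gives 92.9 nM, compound 2 `Cc1nc(S(C)(=O)=O)ccc1Oc1ncnc(OC2CCN(C(=O)OC(C)F)CC2)c1F` gives 65.5 nM, and compound 3 `Cc1nc(S(C)(=O)=O)ccc1Oc1ncnc(OC2CCN(C(=O)SC(C)(C)C)CC2)c1F` gives 4.83 nM. Compound 3 stands lowest of the three, and it is the most potent of them: the step of a 19-fold lower number from compound 1 to compound 3 (1.28 log units; beyond the scatter) and the step of a 14-fold lower number from compound 2 to compound 3 (1.13 log units; beyond the scatter) are both large, whereas the step of a 1.4-fold lower number from compound 1 to compound 2 (0.15 log units; within the scatter) lies within the scatter.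

The next compound, compound 4 `CCC(F)(F)C(=O)N1CCC(Oc2ncnc(Oc3ccc(S(C)(=O)=O)nc3C)c2F)CC1`, departs from compound 3 by the change (1,1-difluoropropyl in place of (tert-butyl)sulfanyl on a carbonyl carbon). Going by the values given here, no measured step covers this exact change. What the measured steps do show is that the (tert-butyl)sulfanyl group on the carbonyl carbon set compound 3 far apart from compounds 1 and 2, which carry 1-cyano-1-methylethoxy and 1-fluoroethyl on an oxygen next to a carbonyl group. Compound 4 gives up that sulfanyl group for one that none of the three measured compounds carries. The expectation is that the number in this assay rises from compound 3 to compound 4, though probably by less than the steps separating compound 3 from compounds 1 and 2. Compound 4 is expected to give about 25 nM in this assay, within a range of 6 nM to 100 nM. On this basis the expected step is a 5.2-fold higher number from compound 3 to compound 4 (0.71 log units; beyond the scatter).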

Compound 4, half-maximal effective concentration: 17.4 nM
Compound 4: the middle estimate sits 1.4-fold (0.16 log units) above what was measured, and the stated range covers the measured number.
By their numbers in this assay, from the lowest: compound 3; then compound 4; then compounds 2 and 1 (each within the scatter of the next).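

In this assay the carbonyl carbon of the shared core can carry a group joined through carbon, with neither sulfur nor oxygen in the link: putting 1,1-difluoropropyl in place of (tert-butyl)sulfanyl gives a 3.6-fold higher number from compound 3 to compound 4 (0.56 log units; beyond the scatter) and so gives up only part of what set compound 3 apart. Measured against the two oxygen-linked groups, the same 1,1-difluoropropyl group gives a 3.8-fold lower number from compound 2 to compound 4 (0.58 log units; beyond the scatter) and a 5.3-fold lower number from compound 1 to compound 4 (0.73 log units; beyond the scatter) and so shows that a low number at this place does not depend on sulfur, although (tert-butyl)sulfanyl remains the best of the four groups. Nothing measured alongside these numbers accounts for the differences between the groups.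

The compounds shown do not separate the contribution of the two fluorines from that of the chain, which a plain propyl group on the same carbonyl carbon would address. Nor do they settle whether the low number of compound 3 belongs to the sulfur link or to the tert-butyl group, which a tert-butoxy group or a tert-butyl group bound directly to the carbonyl carbon would test.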